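The source may report more compounds than this note shows. Statements on the series, on what has been measured and on what is new or still open speak of the compounds shown alone.

Compound 1 `COc1ccc([N+](=O)[O-])cc1CSc1nc2cc(NC(=O)NC(C)(C)C)ccc2n1-c1ccccc1`: > 2600 nM
Compound 2 `COc1ccc([N+](=O)[O-])cc1CSc1nc2cc(NC(=O)C3CCC3)ccc2n1C(C)C`: 630 nM

Of the compounds shown here, two have been tested in an assay on isolated protein for inhibition of Gonadotropin-releasing hormone receptor (Rattus norvegicus); a lower number here means a stronger inhibitor, a higher number a weaker inhibitor. For compound 1 the assay reports only a limit, > 2600 nM, and not a number. Among the compounds with values here, compound 2 gives 630 nM in this assay, the only actual number among the results so far. The other result, (the limit of > 2600 nM in this assay, at which 1 of the 2 values shown sits), is a limit and not a number. Within the data shown here, compound 1 and compound 2 differ in more than one place, so their two values show only that compound 2 was measurable while compound 1 was not within the tested range.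

Compound 3 `CNC(=O)Nc1ccc2c(c1)nc(SCc1cc([N+](=O)[O-])ccc1OC)n2C(C)C` keeps the core of compound 2 and differs in a single spot: methylamino in place of cyclobutyl on a carbonyl carbon. Cut one bond further out, this reads as (cyclobutylcarbonyl)amino becoming (methylcarbamoyl)amino, so an amide becomes a urea. Among the measured compounds shown here, no measured step covers this kind of change. With only one numerical anchor, the expectation is a modest step toward weaker inhibition, a 1.9-fold higher number from compound 2 to compound 3 (0.28 log units; within the scatter), which may not exceed the scatter. Compound 3 is therefore expected to come in at about 1200 nM in this assay, within 300 nM to 5000 nM.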

Compound 3, half-maximal inhibitory concentration: > 10000 nM
Compound 3: no number, only a limit; the forecaster's own chance of this, stated with the estimate: 25%; at least 8.3-fold (0.92 log units) between middle value and limit.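

Replacing cyclobutyl with methylamino on a carbonyl carbon, which turns (cyclobutylcarbonyl)amino into (methylcarbamoyl)amino, gives an at least 15-fold higher number from compound 2 to compound 3 (1.20 log units; beyond the scatter) in this assay. Within the data shown here, this is the first comparison between compounds that differ in one place, and it shows that this position is not indifferent: with the rest of the molecule unchanged, the group on this carbonyl carbon separates a compound with a measurable value from one without. Compound 3 has only a limit and not a number, so the step gives a minimum size and not an exact one: the limit of > 10000 nM in this assay, at which 1 of the 3 values shown sits.

This one change alters several things at once, since the ring leaves, the amide becomes a urea and a hydrogen-bond donor enters, and the compounds shown cannot say which of these matters. A plain methyl on the same carbonyl carbon would keep the amide while removing the ring, and a cyclobutylamino group would keep the ring while making the urea, so these two groups could begin to pull the changes apart.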